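Anilino in Place of Isopentyloxy: Starting From Two Esters

This account rests on a few compounds, and the source may have more. Where it says the series, first, only, none or still open, it means among the compounds named here.

Compound 1, `CCOC(=O)/C(C#N)=C/c1ccoc1`, gives 55.9%.
Compound 2, `CC(C)CCOC(=O)/C(C#N)=C/c1cc2ccccc2[nH]1`, gives 46.6%.

Both numbers come from a functional assay on the whole organism (strain CD1) for inhibition, with Mus musculus as the target, with stated times of 15 min and 20 min, at a dose of 10 mg/kg by the subcutaneous route; on this read-out lower numbers stand for less inhibition and higher numbers for more inhibition at the one dose given (going by the name of the read-out). Of the two, the number for compound 2 is the smaller, yet its gap to compound 1 lies within the usual scatter of repeated runs, so the two cannot be told apart. Compound 3, `N#C/C(=C\c1cc2ccccc2[nH]1)C(=O)Nc1ccccc1`, differs from compound 2 by anilino in place of isopentyloxy on a carbonyl carbon. Among the measured compounds shown here, no step between measured compounds is available to guide the size of this change, so little beyond the scatter is expected in this assay in either direction. Compound 3 is therefore estimated to give 50%, expected to fall between 30% and 70%. The expected step of a number 3.4 percentage points higher from compound 2 to compound 3 (within the scatter) stays within the scatter.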

Compound 3, a percentage reported as inhibition, in the whole organism at one dose (the size of the read-out at that dose, not a potency): 52%
Compound 3: the middle estimate sits 2 percentage points below what was measured; the range from low to high includes it.
By their numbers in this assay, from the lowest: compounds 2, 3 and 1 (each within the scatter of the next).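

In this assay anilino in place of isopentyloxy on a carbonyl carbon gives a number 5.4 percentage points higher from compound 2 to compound 3 (within the scatter) and so cannot be told apart from repeat-to-repeat noise. At this one dose, then, this position accepts an aromatic ring and an amide hydrogen in place of an open chain without a shift that stands out from the scatter. No supporting measurement speaks to the reason for this result. On these data alone, whether a carboxylic acid or a morpholine amide at this carbonyl carbon would move the number beyond the scatter stays open. A single dose also leaves potency unanswered.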